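The source may hold more compounds than are shown below. What is called first, only, known or untested is meant among the compounds shown, and "the series" means these compounds.

Compound 3 (`CCCCNC(=O)CCCOc1ccc(C(=O)c2c(CCCC)oc3ccccc23)cc1`) reads > 50000 nM in a functional assay on MCF7 cells (Homo sapiens) for antiproliferative activity, read by MTT assay, with a stated time of 24 h (a higher number here means a weaker inhibitor, a lower number a stronger inhibitor), and this is a limit, not a number. For comparison, compound 1 (`CCCCc1oc2ccccc2c1C(=O)c1ccc(OCC(=O)N2CCOCC2)cc1`) gives 34000 nM and compound 2 (`CCCCc1oc2ccccc2c1C(=O)c1ccc(OCC(=O)N[C@H](C)c2ccccc2)cc1`) gives 14100 nM.

Compound 4 (`CCCCc1oc2ccccc2c1C(=O)c1ccc(OCCCC(=O)N2CCCCC2)cc1`) carries piperidin-1-yl in place of butylamino on a carbonyl carbon. Among the compounds with values here, no measured step makes this exchange alone. The nearest is an at least 1.4-fold higher number from compound 1 to compound 3 (0.16 log units; that floor lies within the scatter), where morpholin-4-yl on the carbonyl gives way to a butyl amide, with the chain changing as well. Two further steps show that the group on the carbonyl can matter modestly: a 2.4-fold lower number from compound 1 to compound 2 (0.38 log units; beyond the scatter) and an at least 3.5-fold higher number from compound 2 to compound 3 (0.54 log units; beyond the scatter). Both involve the (1-phenylethyl)amino group, which compound 4 lacks, so they bear on it only loosely.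

On the floor of an at least 1.4-fold higher number from compound 1 to compound 3 (0.16 log units; that floor lies within the scatter), no step beyond the scatter is expected in this assay, and compound 4 may again read as a limit. The expected step is an at least 1.1-fold lower number from compound 3 to compound 4 (0.04 log units; that floor lies within the scatter). The estimated value for compound 4 is 45000 nM, with an expected range of 20000 nM to 100000 nM.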

Compound 4, half-maximal inhibitory concentration: 33000 nM
The estimate for compound 4 lay 1.4-fold (0.13 log units) above the measured number; the range from low to high includes it.
By their numbers in this assay, from the lowest: compound 2; then compounds 4 and 1 (each within the scatter of the next). At a limit, above all of these: compound 3.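

In this assay, piperidin-1-yl in place of butylamino on a carbonyl carbon is now seen as a single exchange, and it comes to an at least 1.5-fold lower number from compound 3 to compound 4 (0.18 log units; that floor lies within the scatter). Compound 3 is a limit and not a number, so this step gives only a floor: the limit of > 50000 nM in this assay, at which 1 of the 4 values shown sits. The other two steps change the whole side chain: a 1.0-fold lower number from compound 1 to compound 4 (0.01 log units; within the scatter) leaves the reading within the scatter, while a 2.3-fold higher number from compound 2 to compound 4 (0.37 log units; beyond the scatter) is modest and keeps the (1-phenylethyl)carbamoyl compound as the lower reading.

On these data alone, the true size of the butylamino to piperidin-1-yl step remains open, as do the separate shares of the chain and the carbonyl substituent in the steps from compound 1 and compound 2. Also open, as far as these compounds go, is how a piperazin-1-yl or dimethylamino group on that carbonyl carbon would read.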